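The source may report more compounds than this note shows. Statements on the series, on what has been measured and on what is new or still open speak of the compounds shown alone.

In a functional assay on NCI-H460 cells (Homo sapiens) for cytotoxicity, read by MTT assay, with a stated time of 72 h (a lower number here means a stronger inhibitor, a higher number a weaker inhibitor), the measured compounds are: compound 1 `COc1cc2c(Oc3ccc(NC(=O)c4nnn(-c5ccccc5)c4C)cc3F)ccnc2cc1OCCCN1CCCC1`, 160 nM; compound 2 `COc1cc2c(Oc3ccc(NC(=O)c4nnn(-c5ccccc5C(F)(F)F)c4C)cc3F)ccnc2cc1OCCCN1CCCC1`, 230 nM; compound 3 `COc1cc2c(Oc3ccc(NC(=O)c4nnn(-c5ccc(F)cc5)c4C(F)(F)F)cc3F)ccnc2cc1OCCCN1CCCC1`, 150 nM.

Compound 2 lies within the scatter of both compound 1 and compound 3; the three numbers cannot be separated from one another. Within the data shown here, the only single-point step measured, a 1.4-fold higher number from compound 1 to compound 2 (0.16 log units; within the scatter), is within the scatter and concerns a different part of the molecule.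

Compound 4 `COc1cc2c(Oc3ccc(NC(=O)c4nnn(-c5ccccc5C(F)(F)F)c4C)cc3F)ccnc2cc1OCCCN1CCCCC1` differs from compound 2 by piperidin-1-yl in place of pyrrolidin-1-yl on a saturated chain carbon, three bonds along the chain from an oxygen on an aromatic ring. Among the measured compounds shown here, no measured pair shows this ring enlargement, so nothing speaks for a shift in either direction. The expected step is no change at the digits printed from compound 2 to compound 4 (within the scatter), nothing beyond the scatter. Compound 4 is therefore estimated at 230 nM, with a range from 110 nM to 480 nM.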

Compound 4, half-maximal inhibitory concentration: 280 nM
Estimate against measurement, compound 4: 1.2-fold (0.09 log units) below; measured number inside the range.
By their numbers in this assay, from the lowest: compounds 3, 1, 2 and 4 (each within the scatter of the next).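

In this assay, among these compounds, 3-(piperidin-1-yl)propyl in place of 3-(pyrrolidin-1-yl)propyl gives a 1.2-fold higher number from compound 2 to compound 4 (0.09 log units; within the scatter) and this is the first reading at this position. On the background of compound 2, the saturated ring at the chain end therefore takes the enlargement from five-membered to six-membered without a step beyond the scatter. No supporting data bear on this reading.

Going by these compounds, whether the same holds with the other aryl and triazole substituents of compound 1 and compound 3 stays open. Also open, on these data alone, is what a morpholine ring, a dimethylamino group or a shorter chain would give at this place.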